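From isopropyl to 4-(dipropylamino)butyl

The source may report more compounds than this note shows. Statements on the series, on what has been measured and on what is new or still open speak of the compounds shown alone.

Compound 1 `COc1cc(-c2oc3ccccc3c(=O)c2OC(C)C)cc(OC)c1OC`: > 50000 nM, a limit
Compound 2 `CCN(CC)CCCOc1c(-c2cc(OC)c(OC)c(OC)c2)oc2ccccc2c1=O`: > 50000 nM, a limit
Compound 3 `CCN(CC)CCCCOc1c(-c2cc(OC)c(OC)c(OC)c2)oc2ccccc2c1=O`: 13300 nM

In a functional assay on DU-145 cells (Homo sapiens) for antiproliferative activity, read by WST assay, with a stated time of 3 days (on this read-out higher numbers stand for weaker inhibition and lower numbers for stronger inhibition), compound 1 gives only a limit, > 50000 nM, and not a number. Compound 2 also gives only a limit, > 50000 nM. Compound 1 therefore starts from the limit of > 50000 nM in this assay, at which 2 of the 3 values shown sit.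

The unmeasured compound 4 `CCCN(CCC)CCCCOc1c(-c2cc(OC)c(OC)c(OC)c2)oc2ccccc2c1=O` is reached from compound 1 by one change: 4-(dipropylamino)butyl in place of isopropyl on an oxygen on an aromatic ring. In words, 4-(dipropylamino)butyl takes the place of isopropyl on an oxygen on an aromatic ring.

Among the compounds with values here, no measured compound carries this exact group, so the nearest evidence must serve. Compound 3 is the closest guide, with its value of 13300 nM. Its group, 4-(diethylamino)butyl, sits at the same place, and the result is an at least 3.7-fold lower number from compound 1 to compound 3 (0.57 log units; beyond the scatter). The comparison an at least 3.7-fold lower number from compound 2 to compound 3 (0.57 log units; beyond the scatter) also favours a butyl chain. By contrast, 3-(diethylamino)propyl gives a step that the two limits leave unreadable from compound 1 to compound 2.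

Within the data shown here, a modest step towards a lower number is therefore expected for compound 4 in this assay, similar to the one seen with compound 3, although another limit remains possible. The expected change is an at least 5.0-fold lower number from compound 1 to compound 4 (0.69 log units; beyond the scatter). The estimated value for compound 4 is 10000 nM, with an expected range from 3000 nM to 40000 nM.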

Compound 4, half-maximal inhibitory concentration: 35800 nM
Compound 4: middle estimate off by 3.6-fold (0.55 log units), on the low side, within the range that was stated.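

Within the data shown here, the one step here between two real numbers is a 2.7-fold higher number from compound 3 to compound 4 (0.43 log units; beyond the scatter) in this assay. With the butyl chain kept, the alkyl groups on the nitrogen therefore make a difference, and the dipropylamino end of compound 4 keeps less of the activity seen with the diethylamino end of compound 3. The two other comparisons, an at least 1.3-fold lower number from compound 1 to compound 4 (0.14 log units; that floor lies within the scatter) and an at least 1.3-fold lower number from compound 2 to compound 4 (0.14 log units; that floor lies within the scatter), have floors that do not clear the usual scatter, so 4-(dipropylamino)butyl cannot be said to improve on isopropyl or on 3-(diethylamino)propyl, and both of those steps start from a limit rather than a number: the limit of > 50000 nM in this assay, at which 2 of the 4 values shown sit.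

On these data alone, with only diethylamino and dipropylamino compared on the butyl chain, it stays open whether a smaller amine such as dimethylamino, or a ring amine such as piperidine or morpholine, would give a lower number than compound 3. As far as these compounds go, it also stays open whether a longer chain, such as a pentyl chain ending in diethylamino, would extend the difference seen between compound 2 and compound 3.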